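The compounds below may be only part of what the source reports. "The series", "measured", "known", "first", "only" and "open" are said of these compounds alone.

Measured in a functional assay on MGC-803 cells (Homo sapiens) for antiproliferative activity, read by CCK-8 assay, with a stated time of 72 h, tested at 8 uM; on this read-out higher numbers stand for a stronger effect at the one concentration tested and lower numbers for a weaker effect:
compound 1 `N#Cc1ccc(N2CCN(C(=S)SCc3ccc(C(=O)Nc4ccccc4N)cc3)CC2)cc1`: 37.6%
compound 2 `CN(Cc1ccncc1)C(=S)SCc1ccc(C(=O)Nc2ccccc2N)cc1`: 83.2%
compound 3 `Nc1ccccc1NC(=O)c1ccc(CSC(=S)N2CCCC2)cc1`: 83.4%

Compound 1 stands lowest of the three; compounds 2 and 3 sit far above it, each gap well beyond the scatter, while between those two the step of a number 0.2 percentage points higher from compound 2 to compound 3 (within the scatter) is within the scatter. Compound 4 `Nc1ccccc1NC(=O)c1ccc(CSC(=S)N2CCN(c3cnccn3)CC2)cc1` differs from compound 1 by pyrazin-2-yl in place of 4-cyanophenyl on an amine nitrogen in a ring. Among the compounds with values here, no measured step touches the group on that ring nitrogen; the only measured step concerns the group on the thiocarbonyl carbon and is flat, so nothing in hand sets the size of this change. The expectation is a moderate upward step, a number 17.4 percentage points higher from compound 1 to compound 4 (beyond the scatter), carried with wide uncertainty. Compound 4 is therefore estimated at 55% in this assay, between 30% and 80%.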

Compound 4, a percentage reported as inhibition, at one concentration (the size of the read-out at that concentration, not a potency): 80.5%
Beside the measured number, compound 4's estimate is 25.5 percentage points below it; the measured number lies above the stated range.
By their numbers in this assay, from the lowest: compound 1; then compounds 4, 2 and 3 (each within the scatter of the next).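

In this assay, the group on the amine nitrogen in the ring proves to be a position that matters: a number 42.9 percentage points higher from compound 1 to compound 4 (beyond the scatter) follows pyrazin-2-yl in place of 4-cyanophenyl. Within the data shown here, the only earlier step, on the thiocarbonyl carbon, a number 0.2 percentage points higher from compound 2 to compound 3 (within the scatter), gave no such separation. No measurement here accounts for the size of the new step.

On these data alone, how an unsubstituted phenyl or a pyridin-2-yl on that ring nitrogen would read remains open. As far as these compounds go, with it stays open whether the step tracks the loss of the nitrile or the entry of the pyrazin-2-yl ring nitrogens.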